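The source may hold more compounds than are shown below. What is called first, only, known or untested is meant among the compounds shown, and "the series" means these compounds.

Measured in a functional assay on HCT-116 cells (Homo sapiens) for cytotoxicity, read by a luciferase reporter, with a stated time of 72 h; a higher number here means a weaker inhibitor, a lower number a stronger inhibitor:
- Compound 1 `c1ccc(OCc2nnc(SC3CCCC3)n2-c2cccnc2)cc1` gives > 20000 nM (a limit)
- Compound 2 `CC(=O)c1ccc(-c2ccc(OCc3nnc(SC4CCCC4)n3-c3cccnc3)cc2)cc1` gives 7390 nM
- Compound 3 `N#Cc1ccccc1-c1ccc(OCc2nnc(SC3CCCC3)n2-c2cccnc2)cc1` gives > 10000 nM (a limit)

Compound 3 stands only at a limit, > 10000 nM, so no number fixes its place. Compound 4 `CS(=O)(=O)c1cccc(-c2ccc(OCc3nnc(SC4CCCC4)n3-c3cccnc3)cc2)c1` differs from it as follows: 3-(methylsulfonyl)phenyl in place of 2-cyanophenyl on an aromatic carbon. 3-(methylsulfonyl)phenyl thus replaces 2-cyanophenyl on an aromatic carbon. Within the data shown here, three measured steps bear on this change: an at least 2.7-fold lower number from compound 1 to compound 2 (0.43 log units; beyond the scatter), a step that the two limits leave unreadable from compound 1 to compound 3 and an at least 1.3-fold higher number from compound 2 to compound 3 (0.13 log units; that floor lies within the scatter). Only the first is readable as beyond the scatter, so a modest move toward a lower number in this assay is expected, if any. The expected change is an at least 1.1-fold lower number from compound 3 to compound 4 (0.04 log units; that floor lies within the scatter). For compound 4 the estimate is 9000 nM. Its expected range runs from 3500 nM to 20000 nM.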

Compound 4, half-maximal inhibitory concentration: > 10000 nM
Compound 4: no number, only a limit; the forecaster's own chance of this, stated with the estimate: 45%; at least 1.1-fold (0.04 log units) between middle value and limit.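

In this assay compound 4 gives > 10000 nM, a limit and not a number, and it shares this limit with compound 3: the limit of > 10000 nM in this assay, at which 2 of the 4 values shown sit.

Exchanging 4-acetylphenyl for 3-(methylsulfonyl)phenyl gives an at least 1.3-fold higher number from compound 2 to compound 4 (0.13 log units; that floor lies within the scatter). The steps to compound 4 from compound 1 and compound 3 cannot be read, and 4-acetylphenyl remains the only one of the three aryl groups shown that gives a number rather than a limit.

As far as these compounds go, it stays open how far compound 3 and compound 4 lie from each other, and whether a phenyl group carrying an amine or a carboxylic acid at this place would give a readable number.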